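The source may report more compounds than this note shows. Statements on the series, on what has been measured and on what is new or still open speak of the compounds shown alone.

The measured compounds and their numbers:
Compound 1, `COc1cccc(CNCCCNc2ccnc3cc(-c4ccc(F)cc4)ccc23)c1O`: in a physicochemical assay for acid dissociation, compound 1 gives 9.47.
Compound 2, `COc1ccc(Oc2ccc3c(NCCCNCc4cccc(OC)c4O)ccnc3c2)cc1`: in this assay compound 2 gives 9.28.
Compound 3, `COc1cccc(CNCCCNc2ccnc3cc(Oc4cccc(N(C)C)c4)ccc23)c1O`: in this assay compound 3 gives 9.28.

Compound 3 stands level with compound 2 at the digits shown, the two together the lowest of the three numbers. Its nearest neighbour is compound 2, as seen in no change at the digits printed from compound 2 to compound 3 (within the scatter); the furthest is seen in a number 0.19 log units lower from compound 1 to compound 3 (within the scatter). All three values sit within the scatter of one another, so no order can be read among them.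

Compound 4, `COc1cccc(CNCCCNc2ccnc3cc(Cc4ccccc4)ccc23)c1O`, has not yet been measured. From compound 3 it differs in one place: benzyl in place of 3-(dimethylamino)phenoxy on an aromatic carbon. Among the measured compounds shown here, the steps that bear on this are the earlier swaps at the same aromatic carbon: a number 0.19 log units lower from compound 1 to compound 2 (within the scatter), a number 0.19 log units lower from compound 1 to compound 3 (within the scatter) and no change at the digits printed from compound 2 to compound 3 (within the scatter), each within the scatter. Every time the group on that carbon was exchanged, the acid dissociation constant stayed put. Compound 4 is therefore expected to show no step beyond the scatter, a number 0.07 log units higher from compound 3 to compound 4 (within the scatter). The estimate for compound 4 is 9.35, expected to fall between 9 and 9.7.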

Compound 4, acid dissociation constant: 9.47
Compound 4: the middle estimate sits 0.12 log units below what was measured, within the range that was stated.
By their numbers in this assay, from the lowest: compounds 2, 3, 1 and 4 (each within the scatter of the next).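

In this assay, benzyl on this aromatic carbon is the first group shown whose heavy atoms are all carbon, yet a number 0.19 log units higher from compound 3 to compound 4 (within the scatter) and a number 0.19 log units higher from compound 2 to compound 4 (within the scatter) and no change at the digits printed from compound 1 to compound 4 (within the scatter) all stay inside the usual spread of repeat measurements. The earlier compounds shown here all carried nitrogen, oxygen or fluorine in the group at this carbon, so only now is it seen that a group with none of these atoms also gives a value that this assay cannot tell apart from the others, and this holds for all four compounds without exception. Nothing is available that would explain this flat picture.

On these data alone, what remains open is whether a group of a different kind on this aromatic carbon, such as a carboxylic acid, a primary amine or a longer chain such as phenethyl, would move the number beyond the scatter. All four compounds also share the rest of their structure, so they do not show what a change elsewhere in the molecule, for instance in the propyl chain, would do to this read-out.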